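Cyanoguanidine aryl swap in a rat aorta series

The compounds below may be only part of what the source reports. "The series", "measured", "known", "first", "only" and "open" are said of these compounds alone.

Measured so far:
compound 1 `CC1(C)Oc2ccc(C#N)cc2[C@@H](n2cc(C#N)c3ccccc32)[C@@H]1O` — 2200 nM
compound 2 `CC1(C)Oc2ccc(C#N)cc2[C@@H](/N=C(\NC#N)Nc2cccc(C(F)(F)F)c2)[C@@H]1O` — 1600 nM

In a functional assay (aorta) with Rattus norvegicus as the target (a higher number here means a weaker inhibitor, a lower number a stronger inhibitor), compound 2 gives 1600 nM, and compound 1 gives 2200 nM. The two numbers lie within the scatter of each other, so no order between them is claimed. Compound 3 `CC1(C)Oc2ccc(C#N)cc2[C@@H](/N=C(\NC#N)Nc2ccc(Cl)c(Cl)c2)[C@@H]1O` differs from compound 2 in one place: 3,4-dichlorophenyl in place of 3-(trifluoromethyl)phenyl on an amine nitrogen. No step between measured compounds covers a change of this kind, so nothing shown fixes its size or direction. The step expected a 1.1-fold lower number from compound 2 to compound 3 (0.06 log units; within the scatter) is no larger than the scatter. Compound 3 is expected at 1400 nM, with a range from 500 nM to 4000 nM.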

Compound 3, half-maximal inhibitory concentration: 4600 nM
The estimate for compound 3 lay 3.3-fold (0.52 log units) below the measured number, and the stated range ends below it.
By their numbers in this assay, from the lowest: compounds 2 and 1 (each within the scatter of the next); then compound 3.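

At this amine nitrogen the aryl group matters in this assay: 3,4-dichlorophenyl in place of 3-(trifluoromethyl)phenyl gives a 2.9-fold higher number from compound 2 to compound 3 (0.46 log units; beyond the scatter). Among the compounds shown here, this is the only step read at this position so far, and a single pair sets no trend across aryl groups. Nothing measured on these compounds bears on the result.

On these data alone, whether 3-chlorophenyl or 4-chlorophenyl alone would reproduce the step remains open. Also open, as far as these compounds go, is how unsubstituted phenyl, a pyridine ring or a cyclohexyl group would compare at this nitrogen.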